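Notes on replacing tert-butoxy with tert-butyl

This account rests on a few compounds, and the source may have more. Where it says the series, first, only, none or still open, it means among the compounds named here.

Compound 1 `CC(C)(C)OC[C@@H](O)C(=O)N1[C@H](C(=O)NCc2cc(Cl)ccc2-n2cnnn2)C[C@@H]2C[C@@H]21`: 21 mL.min-1.g-1
Compound 2 `O=C(NCc1cc(Cl)ccc1-n1cnnn1)[C@@H]1[C@@H]2C[C@@H]2CN1C(=O)[C@H](O)Cc1ccccc1`: 74 mL.min-1.g-1

In an ADME assay on liver for metabolic stability, with Liver microsome (Homo sapiens) as the target, read by LC-MS, using microsomes (on this read-out lower numbers stand for slow clearance and higher numbers for fast clearance), compound 1 gives 21 mL.min-1.g-1, the lower of the two numbers, and the gap up to compound 2 lies beyond the scatter. Compound 3 `CC(C)(C)C[C@@H](O)C(=O)N1[C@H](C(=O)NCc2cc(Cl)ccc2-n2cnnn2)C[C@@H]2C[C@@H]21` differs from compound 1 by tert-butyl in place of tert-butoxy on a saturated chain carbon, two bonds along the chain from a carbonyl carbon and an oxygen on a saturated carbon, with tert-butyl in place of tert-butoxy on a saturated chain carbon. For the measured compounds named here, no measured pair isolates this change, so the expectation is loose. A small upward step in this assay is expected, estimated as a 1.4-fold higher number from compound 1 to compound 3 (0.15 log units; within the scatter), probably not beyond the scatter. For compound 3 the estimated value is 30 mL.min-1.g-1, with an expected range of 14 mL.min-1.g-1 to 65 mL.min-1.g-1.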

Compound 3, intrinsic clearance in microsomes: 40 mL.min-1.g-1
Beside the measured number, compound 3's estimate is 1.3-fold (0.12 log units) below it, and the stated range covers the measured number.
By their numbers in this assay, from the lowest: compounds 1, 3 and 2 (each within the scatter of the next, the first and the last beyond it).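

In this assay, tert-butyl in place of tert-butoxy on this saturated chain carbon gives a 1.9-fold higher number from compound 1 to compound 3 (0.28 log units; within the scatter), so this single pair gives a step that does not leave the scatter. At this position, then, the oxygen of tert-butoxy can go without a step beyond the scatter in this read-out. Nothing measured here bears on why the pair reads this way.

On these data alone, whether an amine, a carboxylic acid or a longer chain at this position would stay within the scatter of compound 1 remains open. One pair also leaves open whether this change reads the same on another core.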